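Ethoxyphenyl in Place of Trifluoromethylphenyl: Vero Cell Tolerance

The source may report more compounds than this note shows. Statements on the series, on what has been measured and on what is new or still open speak of the compounds shown alone.

Compound 3 `COC(=O)c1cc(-c2cccc(NC(=O)c3ccc(/C=C/C(=O)c4cccc(C(F)(F)F)c4)cc3)c2)on1` was tested in an ADME assay on Vero cells (Chlorocebus sabaeus) for cytotoxicity, read by MTT assay, with a stated time of 72 h (a higher number here means that more compound is tolerated, a lower number that less compound is tolerated), where compound 3 gives > 20 ug/mL, a limit rather than a number. Compound 1 `COC(=O)c1cc(-c2cccc(NC(=O)c3ccc(/C=C/C(=O)c4cccc(F)c4)cc3)c2)on1` likewise reaches only a limit, > 40 ug/mL. Compound 2 `COC(=O)c1cc(-c2cccc(NC(=O)c3ccc(/C=C/C(=O)c4ccc(F)cc4)cc3)c2)on1` also stops at a limit, > 20 ug/mL. Compound 3 therefore stands at the same kind of limit as both of its neighbours, as the limit of > 20 ug/mL in this assay, at which 2 of the 3 values shown sit, and the limit of > 40 ug/mL in this assay, at which 1 of the 3 values shown sits, show. Compound 4 `CCOc1ccc(C(=O)/C=C/c2ccc(C(=O)Nc3cccc(-c4cc(C(=O)OC)no4)c3)cc2)cc1` differs from compound 3 by 4-ethoxyphenyl in place of 3-(trifluoromethyl)phenyl on a carbonyl carbon. Within the data shown here, the steps that bear on it are a step that the two limits leave unreadable from compound 1 to compound 2, a step that the two limits leave unreadable from compound 1 to compound 3 and a step that the two limits leave unreadable from compound 2 to compound 3, none readable in size. No step beyond the scatter is therefore expected in this assay, and compound 4 is estimated at 40 ug/mL, between 20 ug/mL and 80 ug/mL, an expected step that the limit leaves unreadable from compound 3 to compound 4.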

Compound 4, half-maximal cytotoxic concentration: > 40 ug/mL
Compound 4 gave a limit, no number; the forecaster's own chance of this, stated with the estimate: 80%; the middle value lies on the limit itself.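

Compound 4 reaches only a limit in this assay, as do compound 1, compound 2 and compound 3, so none of the steps to compound 4 can be read. The compounds shown leave open what concentration actually reaches half-maximal cytotoxicity for any of the four.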